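Swapping the benzofuran for thiophene on a weak nucleoside

The compounds below may be only part of what the source reports. "The series", "measured", "known", "first", "only" and "open" are said of these compounds alone.

Compound 1 `COc1nc(N)nc2c1c(-c1cc3ccccc3o1)cn2[C@@H]1O[C@H](CO)[C@@H](O)[C@H]1O` was examined in a functional assay on HL-60 cells (Homo sapiens) for antiproliferative activity, read by XTT assay, with a stated time of 72 h; a higher number here means a weaker inhibitor, a lower number a stronger inhibitor. In this assay compound 1 gives > 20000 nM, which is a limit of the assay and not a number. Compound 2 `Nc1nc(N)c2c(-c3cc4ccccc4o3)cn([C@@H]3O[C@H](CO)[C@@H](O)[C@H]3O)c2n1` carries amino in place of methoxy on an aromatic carbon of the shared core. In this assay compound 2 gives > 15000 nM, again a limit rather than a number. The step that the two limits leave unreadable from compound 1 to compound 2 cannot be read in size because both ends sit at limits, the limit of > 15000 nM in this assay, at which 1 of the 3 values shown sits, and (the limit of > 20000 nM in this assay, at which 1 of the 3 values shown sits). Compound 3 `Cc1ncnc2c1c(-c1ccsc1)cn2[C@@H]1O[C@H](CO)[C@@H](O)[C@H]1O` differs from compound 1 in more than one place. In this assay compound 3 gives 350 nM, a measured number well inside the working range.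

Compound 4 `COc1nc(N)nc2c1c(-c1ccsc1)cn2[C@@H]1O[C@H](CO)[C@@H](O)[C@H]1O` has not yet been measured. It differs from compound 1 by thiophen-3-yl in place of 1-benzofuran-2-yl on an aromatic carbon. For the measured compounds named here, no measured step bears directly on this change: the only measured step, from compound 1 to compound 2, concerns another position and is itself unreadable. Compound 3 shows that a thiophen-3-yl group on a related core can reach a measurable value, but compound 3 differs from compound 4 in more than one place, so it is only a hint. Compound 4 is therefore expected to land near 9000 nM, in the range 1500 nM to 30000 nM, and the expected step of an at least 2.2-fold lower number from compound 1 to compound 4 (0.34 log units; beyond the scatter) is only loosely anchored.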

Compound 4, half-maximal inhibitory concentration: > 20000 nM
Compound 4 was reported as a limit (the forecaster's own chance of this, stated with the estimate: 45%); middle value at least 2.2-fold (0.34 log units) away from the limit.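

In this assay compound 1 and compound 4 both stand at a limit and not at a number, so no step can be read for thiophen-3-yl in place of 1-benzofuran-2-yl: the limit of > 20000 nM in this assay, at which 2 of the 4 values shown sit. The compounds shown leave open how far compound 1 and compound 4 each lie beyond that limit, and which of the several differences separates compound 4 from compound 3.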